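A few compounds are considered here, and "the series" means these few. Any claim that something is new, unique, unknown or untested is made for them only; others in the source may bear on it.

Among the measured compounds shown here, compound 3 `Cc1cc(-c2cccc(C(F)(F)F)c2)cc(C)c1Nc1ccnc(Nc2ccc(C#N)cc2)n1` gives 4030 nM in an ADME assay on MT4 cells (Homo sapiens) for cytotoxicity, read by MTT assay, with a stated time of 4 days (a higher number here means that more compound is tolerated, a lower number that less compound is tolerated), and stands second highest of the three numbers so far, while compound 1 `Cc1cc(-c2ccc(C(F)(F)F)cc2)cc(C)c1Nc1ccnc(Nc2ccc(C#N)cc2)n1` gives 4160 nM and compound 2 `Cc1cc(-c2c(C)cccc2C)cc(C)c1Nc1ccnc(Nc2ccc(C#N)cc2)n1` gives 2590 nM. The steps linking them, a 1.0-fold lower number from compound 1 to compound 3 (0.01 log units; within the scatter) and a 1.6-fold higher number from compound 2 to compound 3 (0.19 log units; within the scatter) as well as a 1.6-fold lower number from compound 1 to compound 2 (0.21 log units; within the scatter), all lie within the scatter. Compound 4 `Cc1cc(-c2ccccc2)cc(C)c1Nc1ccnc(Nc2ccc(C#N)cc2)n1` differs from compound 3 by hydrogen in place of trifluoromethyl on an aromatic carbon. For the measured compounds named here, the steps that bear on this change are those exchanging the group on the same aromatic carbon, and none of them moved the number beyond the scatter, so no step beyond the scatter is expected in this assay for compound 4 either. Compound 4 is therefore estimated at 3600 nM, within 1800 nM to 7500 nM. The expected step is a 1.1-fold lower number from compound 3 to compound 4 (0.05 log units; within the scatter).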

Compound 4, half-maximal cytotoxic concentration: 4170 nM
Beside the measured number, compound 4's estimate is 1.2-fold (0.06 log units) below it, within the range that was stated.
By their numbers in this assay, from the lowest: compounds 2, 3, 1 and 4 (each within the scatter of the next).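

In this assay, among the compounds shown here, the earlier compounds only exchanged one substituted ring for another, whereas compound 4 carries no substituent on that ring, and losing the trifluoromethyl gives a 1.0-fold higher number from compound 3 to compound 4 (0.01 log units; within the scatter) and also a 1.0-fold higher number from compound 1 to compound 4 (0.00 log units; within the scatter) when it starts from the other trifluoromethyl compound. The unsubstituted phenyl ring also stays level with the 2,6-dimethylphenyl ring, with a 1.6-fold higher number from compound 2 to compound 4 (0.21 log units; within the scatter) as the step between them. An amine or a carboxylic acid on this ring remains an open case. No measurement offered here explains why these exchanges leave the number so flat.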